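The source may report more compounds than this note shows. Statements on the series, on what has been measured and on what is new or still open speak of the compounds shown alone.

Measured compounds in a physicochemical assay for solubility, in phosphate buffer; a lower number here means a less soluble compound, a higher number a more soluble compound:
compound 1, `CCOC(=O)c1ccc(Nc2ccnc(-c3cccnc3)n2)cc1`; compound 1 gives 61000 nM.
compound 2, `CCOC(=O)c1ccc(Nc2ccnc(-c3cccnc3)n2)c(F)c1`; compound 2 gives 53000 nM.
compound 3, `CC(=O)c1cccc(Nc2cc(C)nc(-c3cccnc3)n2)c1`; compound 3 gives 95000 nM.

Compound 4, `CC(=O)c1ccc(F)c(Nc2cc(C)nc(-c3cccnc3)n2)c1`, is not yet measured. It differs from compound 3 by fluoro in place of hydrogen on an aromatic carbon. The same kind of change has already been made once, (fluoro in place of hydrogen on an aromatic carbon), and there it produced a 1.2-fold lower number from compound 1 to compound 2 (0.06 log units; within the scatter). The two places are not word for word the same: in compound 2 the entering fluoro stands meta to an ethoxycarbonyl group, in compound 4 para to an acetyl group. The difference between the core of compound 1 and the core of compound 3 is not broken down here. In this assay compound 3 and compound 1 lie within the scatter of each other.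

For compound 4 the expected step is a 1.2-fold lower number from compound 3 to compound 4 (0.07 log units; within the scatter), resting on compound 1 and its step of a 1.2-fold lower number from compound 1 to compound 2 (0.06 log units; within the scatter). Compound 4 is therefore estimated at 80000 nM. For compound 4 the expected range runs from 45000 nM to 140000 nM.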

Compound 4, solubility: 58000 nM
Estimate against measurement, compound 4: 1.4-fold (0.14 log units) above; measured number inside the range.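

In this assay, fluoro in place of hydrogen on an aromatic carbon gives a 1.6-fold lower number from compound 3 to compound 4 (0.21 log units; within the scatter) on the core of compound 3, and a 1.2-fold lower number from compound 1 to compound 2 (0.06 log units; within the scatter) on the core of compound 1; on both cores the step stays within the scatter. For the compounds shown here, this shows that the change produced no readable shift in either of these two pairs, but with only two pairs, and the fluoro differently placed in each, it does not show that the cores respond alike or that other placements would behave the same way. Nothing measured here offers an explanation for either step.

Still open, going by these compounds, is whether the step stays within the scatter when an amine or a carboxylic acid stands in place of the acetyl group. Also open, on these data alone, is whether chloro or methoxy in place of the fluoro would move the number beyond the scatter on either core.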